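The source may report more compounds than this note shows. Statements on the series, on what has been measured and on what is new or still open speak of the compounds shown alone.

The compounds share one core, carrying an oxygen on an aromatic ring from which a side group extends. Compound 1 `CC1CCCC(Oc2cccc3ccc(N)nc23)C1` bears a saturated ring on that oxygen, and in an assay on cells with melanin-concentrating hormone receptor 1 (Homo sapiens) as the target, read by radioligand binding (a higher number here means a weaker inhibitor, a lower number a stronger inhibitor), compound 1 gives 640 nM. Compound 2 `CC#CCCOc1cccc2ccc(N)nc12` bears a short chain with a triple bond instead. In this assay compound 2 reaches only > 2000 nM, a limit of the measurement rather than a number. Compound 2 therefore stands at the limit of > 2000 nM in this assay, at which 1 of the 2 values shown sits, so its true potency is not pinned down. Compound 3 `CC(C)OCCOc1cccc2ccc(N)nc12` has not yet been measured; it differs from compound 2 by isopropoxy in place of prop-1-yn-1-yl on a saturated chain carbon, two bonds along the chain from an oxygen on an aromatic ring. Going by the values given here, with only a limit for compound 2, no measured step shows how large such a change is, and the chain of compound 3 stays unlike the ring of compound 1. The step is expected to be modest, a step that the limit leaves unreadable from compound 2 to compound 3. Compound 3 is estimated at 3000 nM, within a range from 800 nM to 10000 nM.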

Compound 3, half-maximal inhibitory concentration: > 2000 nM
Compound 3 ended at the assay's limit (the forecaster's own chance of this, stated with the estimate: 60%); the middle value is on the limit's open side.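

No step can be read from compound 2 to compound 3, since both stop at a limit of this assay rather than at a number: the limit of > 2000 nM in this assay, at which 2 of the 3 values shown sit. The compounds shown leave open how weak compound 2 and compound 3 truly are, and whether isopropoxy in place of prop-1-yn-1-yl changes potency at all.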